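Swapping a Thiophene for Phenyl on an Inactive Core

This account rests on a few compounds, and the source may have more. Where it says the series, first, only, none or still open, it means among the compounds named here.

Of the compounds shown here, two have been tested so far in a functional assay on MCF7 cells (Homo sapiens) for inhibition, read by sulforhodamine B assay, with a stated time of 48 h; a lower number here means a stronger inhibitor of growth, a higher number a weaker inhibitor of growth. Compound 1, `CC1CCCc2c1nc(N)c(C#N)c2-c1cccn1C`, sits at the limit of the measurement, giving > 100000 nM in this assay. Compound 2, `Cn1cccc1-c1cc(-c2cccs2)[nH]c(=O)c1C#N`, likewise returns only a limit, > 100000 nM in this assay. Compound 2 therefore stands at no number at all: both values shown reach (the limit of > 100000 nM in this assay, at which 2 of the 2 values shown sit), and nothing separates the two compounds on the numbers available. Compound 3, `Cn1cccc1-c1cc(-c2ccccc2)[nH]c(=O)c1C#N`, has not yet been measured. It differs from compound 2 in one place, (phenyl in place of thiophen-2-yl on an aromatic carbon), phenyl in place of thiophen-2-yl on an aromatic carbon. Within the data shown here, no step between measured compounds exists here, so the size of such a change cannot be read from the data. Since compound 2 gives only > 100000 nM in this assay, there is no ground to expect a fall to a measurable number, and the expected step of a number no higher from compound 2 to compound 3 (the limit leaves the size open) is none beyond the scatter. The estimate for compound 3 is 100000 nM, with a range from 30000 nM to 300000 nM, most likely reported again as a limit.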

Compound 3, concentration for 50% growth inhibition: > 100000 nM
Compound 3: only a limit was reported (the forecaster's own chance of this, stated with the estimate: 75%); the middle value sits exactly at the limit.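

Compound 2 and compound 3 both give only a limit in this assay, so the swap of thiophen-2-yl for phenyl yields no readable step between them: the limit of > 100000 nM in this assay, at which 3 of the 3 values shown sit. The compounds shown leave open whether any change to these structures can bring growth inhibition to a measurable number.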